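Swapping the Carbonyl Side Chain of Compound 3

The source may hold more compounds than are shown below. What is called first, only, known or untested is meant among the compounds shown, and "the series" means these compounds.

Measured in a functional assay on HeLa cells (Homo sapiens) for antiproliferative activity, read by MTT assay, with a stated time of 72 h; on this read-out lower numbers stand for stronger inhibition and higher numbers for weaker inhibition:
- compound 1 `C=CC(=O)Nc1cccc(Oc2nc(Nc3cccc(OC)c3)nc3c2CSCC3)c1`: 28900 nM
- compound 2 `CC(C)/C=C/C(=O)Nc1cccc(Oc2nc(Nc3cccc(C#N)c3)nc3c2CSCC3)c1`: 22800 nM
- compound 3 `C=CC(=O)Nc1cccc(Oc2nc(Nc3ccc(OC)nc3)nc3c2CSCC3)c1`: 26300 nM

These three values all lie within the usual scatter of one another. Compound 3, at 26300 nM, therefore stands among them with no real separation from compound 1 or compound 2.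

Compound 4 `COc1ccc(Nc2nc3c(c(Oc4cccc(NC(=O)/C=C/C(C)C)c4)n2)CSCC3)cn1` keeps everything in compound 3 except one group on a carbonyl carbon, where 3-methylbut-1-en-1-yl takes the place of vinyl (3-methylbut-1-en-1-yl in place of vinyl on a carbonyl carbon).

Among the measured compounds shown here, the only measured step with a single change, a 1.1-fold lower number from compound 1 to compound 3 (0.04 log units; within the scatter), concerns a different place, a group on a nitrogen on an aromatic ring. It therefore gives no direct size for this swap. Compound 1 and compound 3 carry vinyl at the carbonyl carbon, whereas compound 2 carries 3-methylbut-1-en-1-yl there and also differs from both elsewhere. With compound 2 at 22800 nM as the closest guide, no step beyond the scatter is expected in this assay.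

The estimated change is a 1.1-fold lower number from compound 3 to compound 4 (0.04 log units; within the scatter). For compound 4 the estimated value is 24000 nM, with an expected range from 12000 nM to 45000 nM.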

Compound 4, half-maximal inhibitory concentration: 27800 nM
Compound 4: middle estimate off by 1.2-fold (0.06 log units), on the low side; the range from low to high includes it.
By their numbers in this assay, from the lowest: compounds 2, 3, 4 and 1 (each within the scatter of the next).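

In this assay, among the compounds shown here, the step of a 1.1-fold higher number from compound 3 to compound 4 (0.02 log units; within the scatter) gives the first direct reading of this swap, with everything else in the molecule held fixed. It shows that replacing vinyl, with 2 heavy atoms, by 3-methylbut-1-en-1-yl, with 5 heavy atoms, on the carbonyl carbon produces no separation beyond the scatter in this antiproliferative read-out. With 3-methylbut-1-en-1-yl kept in place, putting 6-methoxypyridin-3-yl in place of 3-cyanophenyl on the nitrogen gives a 1.2-fold higher number from compound 2 to compound 4 (0.09 log units; within the scatter) and also stays within the scatter, so neither single change shown for compound 4 separates it from its nearest relatives. The data shown offer no evidence that would explain this lack of separation.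

Going by these compounds, what a saturated ethyl group, or a longer chain ending in a dimethylamine, would do on the same carbonyl carbon stays open. Also open, on these data alone, is whether a carboxylic acid on the ring attached to the aromatic nitrogen would move a compound beyond the scatter.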